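Dropping the Chloro Substituent from the Benzyl Group

A few compounds are considered here, and "the series" means these few. Any claim that something is new, unique, unknown or untested is made for them only; others in the source may bear on it.

Compound 3 `O=c1ccoc2cc(OCc3cn(Cc4ccc(Cl)cc4)nn3)ccc12` gives 37600 nM in a functional assay on HeLa cells (Homo sapiens) for cytotoxicity, read by MTT assay, with a stated time of 48 h (on this read-out lower numbers stand for stronger inhibition and higher numbers for weaker inhibition), the highest of the two numbers shown; compound 2 `O=c1ccoc2cc(OCc3cn(Cc4ccc([N+](=O)[O-])cc4)nn3)ccc12` gives 25700 nM, and a 1.5-fold higher number from compound 2 to compound 3 (0.17 log units; within the scatter). Compound 1 `N#Cc1ccc(Cn2cc(COc3ccc4c(=O)ccoc4c3)nn2)cc1` reaches only the assay limit of > 100000 nM in this assay. Compound 4 `O=c1ccoc2cc(OCc3cn(Cc4ccccc4)nn3)ccc12` differs from compound 3 by hydrogen in place of chloro on an aromatic carbon. Among the measured compounds shown here, the steps that bear on this change are an at least 2.6-fold lower number from compound 1 to compound 3 (0.42 log units; beyond the scatter) and an at least 3.8-fold lower number from compound 1 to compound 2 (0.59 log units; beyond the scatter), both swaps of the substituent on the same benzyl ring, together with a 1.5-fold higher number from compound 2 to compound 3 (0.17 log units; within the scatter). Chloro thus gave a lower number than cyano, but no measured pair sets chloro against hydrogen. The expected step is therefore a 1.5-fold higher number from compound 3 to compound 4 (0.17 log units; within the scatter), a mild rise at most. Compound 4 is estimated at 55000 nM, within 20000 nM to 150000 nM.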

Compound 4, half-maximal inhibitory concentration: > 100000 nM
Compound 4 was reported as a limit (the forecaster's own chance of this, stated with the estimate: 25%); middle value at least 1.8-fold (0.25 log units) away from the limit.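

In this assay, the change from 4-chlorobenzyl to benzyl gives an at least 2.6-fold higher number from compound 3 to compound 4 (0.42 log units; beyond the scatter), and hydrogen in place of nitro gives an at least 3.8-fold higher number from compound 2 to compound 4 (0.59 log units; beyond the scatter). Among the compounds shown, the unsubstituted benzyl therefore does not match the chloro or nitro compounds, although compound 1, with its nitrile, shows that not every substituent here lowers the number. The step between compound 1 and compound 4 cannot be read, since both values are limits: the limit of > 100000 nM in this assay, at which 2 of the 4 values shown sit.

Going by these compounds, whether an amine or a carboxylic acid at this place would give a lower number than chloro or nitro remains open.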